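A Second Trifluoromethyl Group on the Urea Aryl Ring

A few compounds are considered here, and "the series" means these few. Any claim that something is new, unique, unknown or untested is made for them only; others in the source may bear on it.

Compound 1 `O=C(Nc1cccc(-n2cc(-c3ccncc3)c(-c3ccc(Cl)c(O)c3)n2)c1)Nc1cccc(C(F)(F)F)c1` was tested in a functional assay on HT-29 cells (Homo sapiens) for inhibition, read by sulforhodamine B assay, with a stated time of 48 h; a higher number here means that more compound is tolerated, a lower number that less compound is tolerated. In this assay compound 1 gives only the assay limit of > 32500 nM, not a number. Compound 2 `O=C(Nc1cccc(-n2cc(-c3ccncc3)c(-c3ccc(Cl)c(O)c3)n2)c1)Nc1ccc(Cl)c(Cl)c1` is its close relative, and between them lies a step that the two limits leave unreadable from compound 1 to compound 2. For compound 2 this assay likewise reports only the limit of > 32500 nM. Both measured values sit at the limit of > 32500 nM in this assay, at which 2 of the 2 values shown sit, so no step size can be read from them. Compound 3 `O=C(Nc1cccc(-n2cc(-c3ccncc3)c(-c3ccc(Cl)c(O)c3)n2)c1)Nc1cc(C(F)(F)F)cc(C(F)(F)F)c1` differs from compound 1 by trifluoromethyl in place of hydrogen on an aromatic carbon. The step from compound 1 to compound 3 is expected to be a step that the limit leaves unreadable from compound 1 to compound 3, most likely again ending at a limit. For compound 3 the estimate is 40000 nM, within 12000 nM to 130000 nM.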

Compound 3, concentration lethal to 50% of the cells: 4670 nM
The estimate for compound 3 lay 8.6-fold (0.93 log units) above the measured number; the measured number lies below the stated range.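

Among these compounds, replacing hydrogen with trifluoromethyl on this aromatic carbon, meta to a trifluoromethyl group, gives the first step whose size can be estimated: an at least 6.9-fold lower number from compound 1 to compound 3 (0.84 log units; beyond the scatter). The cells therefore tolerate less of the compound once this second trifluoromethyl group is present, whereas the step from compound 1 to compound 2 cannot be read. Only compound 3 gives an actual number, and the other two stay at the limit: the limit of > 32500 nM in this assay, at which 2 of the 3 values shown sit.

The compounds shown leave open whether a methyl group, an amine or a carboxylic acid on this carbon would also lower the number. They also leave open how far the number would move with each of these groups.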